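Two Thiophene Swaps on Related Fused Cores

The compounds below may be only part of what the source reports. "The series", "measured", "known", "first", "only" and "open" are said of these compounds alone.

Compound 1 `N=C(N)N/N=C/c1c(-c2cccs2)nc2sccn12` gives 8320 nM in a functional assay on cells (Cancer cell lines, Homo sapiens) for inhibition; on this read-out lower numbers stand for stronger inhibition of growth and higher numbers for weaker inhibition of growth. Compound 2 `Cc1cc(-c2nc3sccn3c2/C=N/NC(=N)N)c(C)s1` gives 17800 nM in this assay, and compound 3 `Cc1cc(-c2nc3n(c2/C=N/NC(=N)N)CCS3)c(C)s1` gives 17400 nM; the difference between the cores of compound 2 and compound 3 is not broken down here. The change thiophen-2-yl in place of 2,5-dimethylthiophen-3-yl on an aromatic carbon produced a 2.1-fold lower number from compound 2 to compound 1 (0.33 log units; beyond the scatter), a modest step. Compound 4 `N=C(N)N/N=C/c1c(-c2cccs2)nc2n1CCS2` has not yet been measured in this assay. It arises from compound 3 by the same kind of change, (thiophen-2-yl in place of 2,5-dimethylthiophen-3-yl on an aromatic carbon), the place here additionally lying two ring bonds from two ring atoms that each bear a fused ring. Because the earlier swap gave a 2.1-fold lower number from compound 2 to compound 1 (0.33 log units; beyond the scatter), compound 4 is expected to give 8500 nM in this assay, an estimated step of a 2.0-fold lower number from compound 3 to compound 4 (0.31 log units; beyond the scatter), with a likely range from 4000 nM to 18000 nM.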

Compound 4, concentration for 50% growth inhibition: 22900 nM
For compound 4 the middle estimate is 2.7-fold (0.43 log units) below the measured one; measured number above the stated range.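

Moved to the second core, the change to thiophen-2-yl gave a 1.3-fold higher number from compound 3 to compound 4 (0.12 log units; within the scatter) in this assay, so the lower number seen on the first core did not recur. The two steps do not agree, and the gap between them exceeds what repeated measurement would explain: the same change on two cores in this assay, a 2.1-fold lower number (0.33 log units; beyond the scatter) from compound 2 to compound 1 and a 1.3-fold higher number (0.12 log units; within the scatter) from compound 3 to compound 4, 2.8-fold (0.45 log units) apart, beyond the scatter of two such steps

Among these compounds, this shows that the swap cannot simply be carried from one of these cores to the other, but with only two pairs it does not show which feature of the cores is responsible or how the change would behave on a further core.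

The compounds shown leave open whether a thiophene bearing a single methyl, or a phenyl group in the same place, would behave alike on both cores.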